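Two measured analogues and a bulkier aryl substituent to come

This account rests on a few compounds, and the source may have more. Where it says the series, first, only, none or still open, it means among the compounds named here.

Compound 1 `Cn1ccc2c(Oc3ccc(NC(=O)c4cc5cccnc5n(-c5ccc(F)cc5)c4=O)cc3)ccnc21`, a functional assay on NCI-H460 cells (Homo sapiens) for antiproliferative activity, read by MTT assay, with a stated time of 72 h; on this read-out higher numbers stand for weaker inhibition and lower numbers for stronger inhibition: 260 nM
Compound 2 `Cn1ccc2c(Oc3ccc(NC(=O)c4cc5cccnc5n(-c5ccc(F)cc5)c4=O)cc3F)ccnc21`, this assay: 250 nM

Compound 2 stands lowest of the two numbers, yet its nearest neighbour is compound 1, and the step of a 1.0-fold lower number from compound 1 to compound 2 (0.02 log units; within the scatter) lies within the scatter, so no order between them can be read. Compound 3 `Cn1ccc2c(Oc3ccc(NC(=O)c4cc5cccnc5n(-c5ccc(C(F)(F)F)cc5Cl)c4=O)cc3F)ccnc21` differs from compound 2 in one place: 2-chloro-4-(trifluoromethyl)phenyl in place of 4-fluorophenyl on an aromatic nitrogen. Among the measured compounds shown here, the only measured step, from compound 1 to compound 2, changes a different part of the molecule, so no step in these data bears on this exchange. Without a comparable precedent, compound 3 is expected to remain near compound 2, with a wide range on either side, and the step of no change at the digits printed from compound 2 to compound 3 (within the scatter) is an estimate carrying no directional support. Compound 3 is therefore estimated at 250 nM, between 80 nM and 800 nM.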

Compound 3, half-maximal inhibitory concentration: 6010 nM
For compound 3 the middle estimate is 24-fold (1.38 log units) below the measured one; measured number outside the range, above it.
By their numbers in this assay, from the lowest: compounds 2 and 1 (each within the scatter of the next); then compound 3.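

In this assay, among the compounds shown here, the exchange on the aromatic nitrogen gives a 24-fold higher number from compound 2 to compound 3 (1.38 log units; beyond the scatter), and this is the first step that lies beyond the scatter. The aryl group at this position therefore has a strong bearing on the read-out, and 2-chloro-4-(trifluoromethyl)phenyl is much less well tolerated here than 4-fluorophenyl, whereas the earlier fluoro exchange elsewhere in the molecule left the number unresolved. No measurement here explains why the number rises so sharply.

The step replaces 4-fluorophenyl with a group carrying both chloro and trifluoromethyl, so the shares of these two substituents cannot be separated. Going by these compounds, it remains open how 2-chlorophenyl, 4-(trifluoromethyl)phenyl or a simple unsubstituted phenyl would compare at this nitrogen, and whether a 4-aminophenyl or 4-carboxyphenyl group would be accepted there.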